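The source may report more compounds than this note shows. Statements on the series, on what has been measured and on what is new or still open speak of the compounds shown alone.

In an ADME assay on Akata cells (Homo sapiens) for cytotoxicity, with a stated time of 7 days (a lower number here means that less compound is tolerated, a higher number that more compound is tolerated), three compounds on one shared core have been measured, and none of them gives a number. Compound 1 `Nc1nc(NCc2ccccc2)c2ncn(/C=C3/CC3(CO)CO)c2n1` gives > 24000 nM, which is a limit of the assay. Compound 2 `CC(C)Nc1nc(N)nc2c1ncn2/C=C1/CC1(CO)CO` gives > 24000 nM, also a limit. Compound 3 `Nc1nc(NC2CCCC2)c2ncn(/C=C3/CC3(CO)CO)c2n1` gives > 20000 nM, again a limit, so its place relative to the other two cannot be read.

The next compound departs further from this group. Compound 4 `CCCCCCCCSc1nc(N)nc2c1ncn2/C=C1/CC1(CO)CO` carries octylsulfanyl in place of cyclopentylamino on an aromatic carbon, and the change from compound 3 is octylsulfanyl in place of cyclopentylamino on an aromatic carbon.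

The measured steps that bear on this are a step that the two limits leave unreadable from compound 1 to compound 2, a step that the two limits leave unreadable from compound 1 to compound 3 and a step that the two limits leave unreadable from compound 2 to compound 3. Each of them exchanges only the group on the nitrogen, and none has a size that can be read. They therefore offer no measured guide to a change that removes the nitrogen as well, and any expectation for it remains loose.

A move towards less compound being tolerated in this assay is expected, though compound 4 may also end as a limit. The expected change is an at least 1.6-fold lower number from compound 3 to compound 4 (0.22 log units; that floor lies within the scatter). For compound 4 the estimated value is 12000 nM, with an expected range from 3000 nM to 30000 nM.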

Compound 4, half-maximal cytotoxic concentration: > 20000 nM
Compound 4 ended at the assay's limit; the forecaster's own chance of this, stated with the estimate: 40%; at least 1.6-fold (0.22 log units) between middle value and limit.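

Compound 4 gives > 20000 nM, which is again a limit of the assay, so its steps from compound 1, compound 2 and compound 3 cannot be read. The compounds shown leave open how these four compounds truly rank in this assay, and whether any group at this place on the shared core gives a measurable half-maximal cytotoxic concentration.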